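Aryl swap on the saturated ring carbon, compound 4

This account rests on a few compounds, and the source may have more. Where it says the series, first, only, none or still open, it means among the compounds named here.

Measured so far:
- compound 1 `O=CCN1N=C(c2ccc3ccccc3c2)CC1c1cccc([N+](=O)[O-])c1`: 3280 nM
- compound 2 `O=CCN1N=C(c2ccc3ccccc3c2)CC1c1cccc(Br)c1`: 9870 nM
- compound 3 `O=CCN1N=C(c2ccc3ccccc3c2)CC1c1ccco1`: 11000 nM

All three share one core and differ only in the group on the saturated ring carbon. In a functional assay on IMR-32 cells (Homo sapiens) for cytotoxicity, read by sulforhodamine B assay, with a stated time of 48 h (on this read-out lower numbers stand for stronger inhibition and higher numbers for weaker inhibition), compound 1 gives 3280 nM, compound 2 gives 9870 nM and compound 3 gives 11000 nM. Compound 3 stands at the highest number of the three; its gap to compound 2 is within the scatter, while a 3.4-fold higher number from compound 1 to compound 3 (0.53 log units; beyond the scatter) is beyond it.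

Compound 4 `COc1ccc(C2CC(c3ccc4ccccc4c3)=NN2CC=O)cc1` is not yet measured. The change is 4-methoxyphenyl in place of furan-2-yl on a saturated ring carbon.

Two measured steps end at compound 3 and bear on the same position: a 3.4-fold higher number from compound 1 to compound 3 (0.53 log units; beyond the scatter) and a 1.1-fold higher number from compound 2 to compound 3 (0.05 log units; within the scatter). Replacing an aryl group on this carbon by furan-2-yl thus gave either a modest rise or no change beyond the scatter. Reversing the direction, a six-membered carbon ring in place of furan-2-yl, is expected to give at most a modest lower number, or none beyond the scatter; the 4-methoxyphenyl group itself has no precedent here, so the expectation is loose.

For compound 4 the estimated step is a 1.4-fold lower number from compound 3 to compound 4 (0.14 log units; within the scatter) in this assay. Compound 4 is therefore estimated at 8000 nM, with a range from 3000 nM to 20000 nM.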

Compound 4, half-maximal inhibitory concentration: 4120 nM
For compound 4 the middle estimate is 1.9-fold (0.29 log units) above the measured one; low and high end bracket the measured number.
By their numbers in this assay, from the lowest: compounds 1 and 4 (each within the scatter of the next); then compounds 2 and 3 (each within the scatter of the next).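

In this assay, 4-methoxyphenyl in place of furan-2-yl gives a 2.7-fold lower number from compound 3 to compound 4 (0.43 log units; beyond the scatter) and 4-methoxyphenyl in place of 3-bromophenyl gives a 2.4-fold lower number from compound 2 to compound 4 (0.38 log units; beyond the scatter) on the same saturated ring carbon. The earlier compounds shown here left 3-nitrophenyl alone at the low end of the series, whereas 4-methoxyphenyl in place of 3-nitrophenyl gives a 1.3-fold higher number from compound 1 to compound 4 (0.10 log units; within the scatter) and so places no order between these two groups. A low number at this position is therefore not confined to the nitro-bearing ring, yet a six-membered aromatic ring of carbon only is not sufficient for it, since compound 2 carries such a ring and stays within the scatter of compound 3.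

Still open, from the compounds shown here alone, is how an unsubstituted phenyl, an amine or a carboxylic acid on the aryl ring, or a longer chain in place of the ring would read at this carbon. Equally open, going by these compounds, is whether the methoxy group would give the same number at another ring position, or whether the steps seen here hold with a group other than formylmethyl on the ring nitrogen.

No measurement at hand explains these differences.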